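Swapping hydroxy for chloro in a three-compound series

The compounds below may be only part of what the source reports. "The series", "measured", "known", "first", "only" and "open" are said of these compounds alone.

Of the compounds shown here, three with a shared core have been tested so far in a functional assay on the whole organism (Hindlimb, strain albino) with Mus musculus as the target, in the maximal electroshock model, with a stated time of 0.5 h; a lower number here means that less compound is needed, a higher number that more compound is needed for the effect. Compound 1 (`COc1ccc(/C=C/C(=O)Nc2nc3ccc([N+](=O)[O-])cc3s2)cc1`) gives 315 umol/kg, compound 2 (`O=C(/C=C/c1ccccc1)Nc1nc2ccc([N+](=O)[O-])cc2s1`) gives 485 umol/kg, and compound 3 (`O=C(/C=C/c1ccc(O)cc1)Nc1nc2ccc([N+](=O)[O-])cc2s1`) gives 382 umol/kg. Compound 3 lies within the usual scatter of both other compounds, so these three numbers cannot be ranked with confidence.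

Compound 4 (`O=C(/C=C/c1ccc(Cl)cc1)Nc1nc2ccc([N+](=O)[O-])cc2s1`) has chloro in place of hydroxy on an aromatic carbon of compound 3: chloro in place of hydroxy on an aromatic carbon. Among the measured compounds shown here, no chloro compound has been measured yet, so the only guide is how changes at this same carbon have behaved. Hydroxy in place of hydrogen gives a 1.3-fold lower number from compound 2 to compound 3 (0.10 log units; within the scatter). Hydrogen in place of methoxy gives a 1.5-fold higher number from compound 1 to compound 2 (0.19 log units; within the scatter). Hydrogen in place of methyl on the oxygen gives a 1.2-fold higher number from compound 1 to compound 3 (0.08 log units; within the scatter). All three steps stay within the scatter, so no clear shift is expected in this assay. The expected step is a 1.1-fold lower number from compound 3 to compound 4 (0.05 log units; within the scatter). The estimate for compound 4 is 340 umol/kg, with an expected range of 170 umol/kg to 680 umol/kg.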

Compound 4, dose for half-maximal effect: 259 umol/kg
Compound 4: middle estimate off by 1.3-fold (0.12 log units), on the high side, and the stated range covers the measured number.
By their numbers in this assay, from the lowest: compounds 4, 1, 3 and 2 (each within the scatter of the next).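

Chloro has no hydrogen-bond donor or acceptor where hydroxy has one of each, yet in this assay this swap gives a 1.5-fold lower number from compound 3 to compound 4 (0.17 log units; within the scatter) and no more. Chloro in place of hydrogen gives a 1.9-fold lower number from compound 2 to compound 4 (0.27 log units; within the scatter) as the widest step seen so far, while chloro in place of methoxy gives a 1.2-fold lower number from compound 1 to compound 4 (0.09 log units; within the scatter) in this series. This carbon has now carried four different groups with every step staying inside the scatter, and nothing available here bears on why the numbers differ at all.

Going by these compounds, it remains open whether an amine, a carboxylic acid or a longer chain on this carbon would take the number beyond the scatter. On these data alone, it is equally open whether replacing the nitro group on the shared core would do so.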